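From carboxy to pyridin-3-yl on a shared core

The source may report more compounds than this note shows. Statements on the series, on what has been measured and on what is new or still open speak of the compounds shown alone.

In an in vitro ADME assay on microsomes from liver (Mus musculus) for metabolic stability, tested at 0.2 uM (a higher number here means faster removal of the compound, a lower number slower removal), compound 1 `COc1ccc2[nH]c(COc3cccc(OCC4CCOCC4)c3)c(C)c(=O)c2c1` is recorded as "not determined" (no result reported), and compound 2 `Cc1c(COc2cccc(OCC3CCOCC3)c2)[nH]c2ccc(Br)cc2c1=O` as "not determined" (no result reported). Compound 3 `Cc1c(COc2cccc(OCC3CCOCC3)c2)[nH]c2ccc(C(=O)O)cc2c1=O` gives < 50 mL/min/kg, which is a limit of the assay and not a number. Among the measured compounds shown here, compound 3 thus offers the only reading of the three, and even that lacks an exact figure. Compound 4 `Cc1c(COc2cccc(OCC3CCOCC3)c2)[nH]c2ccc(-c3cccnc3)cc2c1=O` carries pyridin-3-yl in place of carboxy on an aromatic carbon. No measured step among these compounds bears on this change, so any expectation remains rough. In this assay the estimate means an at least 1.6-fold higher number from compound 3 to compound 4 (0.20 log units; that floor lies within the scatter), an expected rise that probably lies beyond the scatter. Compound 4 is estimated at 80 mL/min/kg, with an expected range of 45 mL/min/kg to 180 mL/min/kg.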

Compound 4, clearance: > 1000 mL/min/kg
Compound 4: only a limit was reported (the forecaster's own chance of this, stated with the estimate: 30%); middle value at least 12-fold (1.09 log units) away from the limit.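

Pyridin-3-yl in place of carboxy on this aromatic carbon of the shared core gives, in this assay, an at least 20-fold higher number from compound 3 to compound 4 (1.30 log units; beyond the scatter), so the group held here can strongly change the reading. Compound 3 rests on a limit of the assay: the limit of < 50 mL/min/kg in this assay, at which 1 of the 4 values shown sits. Compound 4 also rests on a limit: the limit of > 1000 mL/min/kg in this assay, at which 1 of the 4 values shown sits.

Steps involving compound 1 and compound 2 cannot be read. From the compounds shown here alone, with only these two end groups, it remains open where an amide or a phenyl ring at this position would fall, and whether the ring or the loss of carboxy matters more.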